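A few compounds are considered here, and "the series" means these few. Any claim that something is new, unique, unknown or untested is made for them only; others in the source may bear on it.

Working notes on the series in a functional assay on B16-F10 cells (Mus musculus) for antiproliferative activity, read by ELISA and MTT assay, with a stated time of 48 h; a higher number here means a weaker inhibitor, a lower number a stronger inhibitor. Compound 1 `O=C(/C=C/c1ccccc1)NS(=O)(=O)c1ccccc1` gives 3.5 ug/mL. Compound 2 `O=C(/C=C/c1ccccc1)NS(=O)(=O)c1ccc(Br)cc1` gives 3.9 ug/mL, and the step of a 1.1-fold higher number from compound 1 to compound 2 (0.05 log units; within the scatter) is small. The two cores differ by hydrogen in place of bromo on an aromatic carbon. Compound 3 `O=C(/C=C/c1ccc([N+](=O)[O-])cc1)NS(=O)(=O)c1ccc(Br)cc1` gives 13.9 ug/mL, reached through the step of a 3.6-fold higher number from compound 2 to compound 3 (0.55 log units; beyond the scatter), brought by nitro in place of hydrogen on an aromatic carbon.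

Compound 4 `O=C(/C=C/c1ccccc1[N+](=O)[O-])NS(=O)(=O)c1ccccc1` has not been measured. It differs from compound 1 by nitro in place of hydrogen on an aromatic carbon. This is the same kind of change as that from compound 2 to compound 3, but not the same: there the entering nitro sits para to a large group, here it sits ortho to a large group, and the cores differ as told above. For compound 4 the step expected is a 2.9-fold higher number from compound 1 to compound 4 (0.46 log units; beyond the scatter), resting on the measured step of a 3.6-fold higher number from compound 2 to compound 3 (0.55 log units; beyond the scatter) while allowing a wide margin for the different place of the change and the different core. Compound 4 is thus expected to give about 10 ug/mL in this assay, with a range from 4 ug/mL to 25 ug/mL.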

Compound 4, half-maximal inhibitory concentration: 6 ug/mL
The estimate for compound 4 lay 1.7-fold (0.22 log units) above the measured number; the range from low to high includes it.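

In this assay, nitro in place of hydrogen on an aromatic carbon gives a 1.7-fold higher number from compound 1 to compound 4 (0.23 log units; within the scatter), so on the core of compound 1 this change cannot be told apart from no change. Set beside the earlier step, the result gives no sign that the two cores respond differently: the same change on two cores in this assay, a 3.6-fold higher number (0.55 log units; beyond the scatter) from compound 2 to compound 3 and a 1.7-fold higher number (0.23 log units; within the scatter) from compound 1 to compound 4, 2.1-fold (0.32 log units) apart, within the scatter of two such steps
This shows that the two readings are compatible, but it does not show that the change carries over with a fixed size, since each core offers a single pair, the nitro of compound 4 sits ortho to a large group while that of compound 3 sits elsewhere, and place and core cannot be separated here.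

The compounds shown leave open how nitro would behave in the same place on each of the two cores. They also leave open whether an amine or a carboxylic acid on the same ring would follow the steps seen with nitro.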